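The source may hold more compounds than are shown below. What is called first, only, known or untested is meant among the compounds shown, and "the series" means these compounds.

Measured compounds:
compound 1, `Cn1ccc(-c2cccc3c2CCC3c2ncc[nH]2)n1`, 19%
compound 2, `COc1cccc2c1CCC2c1ncc[nH]1`, 65%

Among the measured compounds shown here, in a functional assay on CHO cells for agonist activity at Alpha-1A adrenergic receptor (Homo sapiens), read by FLIPR and calcium flux (a higher number here means a larger maximal response, a lower number a smaller maximal response), compound 2 gives 65%, the higher of the two numbers so far; compound 1 gives 19%. For the measured compounds named here, the one measured step, a number 46 percentage points higher from compound 1 to compound 2 (beyond the scatter), lies beyond the scatter. Compound 3, `Cn1nccc1-c1cccc2c1CCC2c1ncc[nH]1`, is not yet measured. It differs from compound 2 by 1-methyl-1H-pyrazol-5-yl in place of methoxy on an aromatic carbon. This is close to the reverse of the measured step: a methyl-pyrazolyl ring, here named 1-methyl-1H-pyrazol-5-yl rather than 1-methyl-1H-pyrazol-3-yl, again takes the place of methoxy on the aromatic carbon. Going by the values given here, because a number 46 percentage points higher from compound 1 to compound 2 (beyond the scatter) was large, a large step downward is expected in this assay, although only a single step is available and the pyrazolyl ring of compound 3 carries a different name, so the size remains uncertain. Compound 3 is therefore expected to give 25%, within 10% to 45%, an estimated step of a number 40 percentage points lower from compound 2 to compound 3 (beyond the scatter).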

Compound 3, largest response reached (Emax), in percent of the reference or control that the assay uses: 58%
For compound 3 the middle estimate is 33 percentage points below the measured one, outside the stated range (above it).
By their numbers in this assay, from the lowest: compound 1; then compounds 3 and 2 (each within the scatter of the next).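

At this aromatic carbon of the shared core, 1-methyl-1H-pyrazol-5-yl in place of methoxy gives a number 7 percentage points lower from compound 2 to compound 3 (within the scatter) in this assay, so a methyl-pyrazolyl ring as such does not bring the low response of compound 1. The attachment of the ring carries the difference: 1-methyl-1H-pyrazol-5-yl in place of 1-methyl-1H-pyrazol-3-yl gives a number 39 percentage points higher from compound 1 to compound 3 (beyond the scatter), a large step between two groups with the same heavy-atom count at the same carbon. Nothing available accounts for this gap between the two pyrazolyl groups.

From the compounds shown here alone, whether the response at this carbon depends on the methyl on the pyrazole stays open, as a pyrazolyl ring without that methyl would be needed to tell. Also open, going by these compounds, is how an amine, a carboxylic acid or a longer alkoxy chain at this carbon would read in this assay against methoxy.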